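This account rests on a few compounds, and the source may have more. Where it says the series, first, only, none or still open, it means among the compounds named here.

Working notes on the series, read in a toxicity assay on MDCK cells (Canis lupus familiaris) for cytotoxicity, read by CCK-8 assay, with a stated time of 48 h; on this read-out lower numbers stand for higher toxicity in this test and higher numbers for lower toxicity in this test. Compound 1 (`CCOc1ccc(C(=O)NNc2c(Br)cccc2Br)cc1`) gives > 100000 nM, which is a limit and not a number. Compound 2 (`CCCCOc1ccc(C(=O)NNc2c(Br)cccc2Br)cc1`) gives > 100000 nM, also a limit. Compound 3 (`O=C(NNc1c(Br)cccc1Br)c1ccc(OCC(F)(F)F)cc1`) gives > 100000 nM, again a limit, so compound 3 has no number and shares its place with the other two (the limit of > 100000 nM in this assay, at which 3 of the 3 values shown sit).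

Compound 4 (`CC(C)(C)c1ccc(C(=O)NNc2c(Br)cccc2Br)cc1`) carries tert-butyl in place of 2,2,2-trifluoroethoxy on an aromatic carbon, para to a large group (tert-butyl in place of 2,2,2-trifluoroethoxy on an aromatic carbon).

The nearest measured steps all change the chain on the ring oxygen: a step that the two limits leave unreadable from compound 1 to compound 2, a step that the two limits leave unreadable from compound 1 to compound 3 and a step that the two limits leave unreadable from compound 2 to compound 3. None of the three has a readable size, and none removes that oxygen, so they give only weak guidance.

In this assay, no step beyond the scatter is expected, and no direction can be assigned. The estimated step is a number no higher from compound 3 to compound 4 (the limit leaves the size open), which rests on the shared limit (the limit of > 100000 nM in this assay, at which 3 of the 3 values shown sit). For compound 4 the estimated value is 100000 nM, with an expected range from 40000 nM to 200000 nM.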

Compound 4, half-maximal cytotoxic concentration: > 100000 nM
Compound 4: no number, only a limit; the forecaster's own chance of this, stated with the estimate: 75%; the middle value sits exactly at the limit.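

Compound 4 gives > 100000 nM as a limit and not a number. For the compounds shown here, no step among compound 1, compound 2, compound 3 and compound 4 can be read, since all four share one limit: the limit of > 100000 nM in this assay, at which 4 of the 4 values shown sit. The compounds shown leave open what number any of the four would have on this read-out.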